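The compounds below may be only part of what the source reports. "The series", "measured", "known", "first", "only" and "open" are said of these compounds alone.

Measured so far:
- compound 1 `COc1ccc([C@H](O)[C@H]2CO[C@@H](c3ccc(OC)c(OC)c3)[C@H](C/C=C/c3ccccc3)C2)cc1OC`: 16100 nM
- compound 2 `O[C@@H](c1ccccc1)[C@H]1CO[C@H](c2ccccc2)[C@@H](C/C=C/c2cccc(F)c2)C1`: 8380 nM
- compound 3 `Oc1ccc(/C=C/C[C@H]2C[C@@H]([C@@H](O)c3ccccc3)CO[C@@H]2c2ccccc2)cc1`: 14400 nM

In a functional assay on HeLa cells (Homo sapiens) for cytotoxicity, read by WST assay, with a stated time of 48 h (a higher number here means a weaker inhibitor, a lower number a stronger inhibitor), compound 1 gives 16100 nM, within the scatter of the other two values. Compound 4 `COc1cccc(/C=C/C[C@@H]2C[C@@H]([C@@H](O)c3ccc(OC)c(OC)c3)CO[C@H]2c2ccc(OC)c(OC)c2)c1` is still unmeasured. It differs from compound 1 by methoxy in place of hydrogen on an aromatic carbon, turning 3-phenylprop-2-en-1-yl into 3-(3-methoxyphenyl)prop-2-en-1-yl. For the measured compounds named here, the only measured step on that phenyl is a 1.7-fold higher number from compound 2 to compound 3 (0.24 log units; within the scatter), which exchanges other groups and stays within the scatter. Going by the values given here, no measured pair tests methoxy there, so no shift beyond the scatter is expected in this assay. The estimated change is a 1.2-fold lower number from compound 1 to compound 4 (0.06 log units; within the scatter). For compound 4 the expected value is 14000 nM, with an estimated range of 6500 nM to 30000 nM.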

Compound 4, half-maximal inhibitory concentration: 16400 nM
Beside the measured number, compound 4's estimate is 1.2-fold (0.07 log units) below it, and the stated range covers the measured number.
By their numbers in this assay, from the lowest: compounds 2, 3, 1 and 4 (each within the scatter of the next).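

Methoxy in place of hydrogen on this phenyl now has a direct test, whereas the earlier step exchanged other groups: in this assay the change gives a 1.0-fold higher number from compound 1 to compound 4 (0.01 log units; within the scatter). Turning 3-phenylprop-2-en-1-yl into 3-(3-methoxyphenyl)prop-2-en-1-yl therefore produces no shift beyond the scatter on the core of compound 1. No supporting measurement bears on this result.

As far as these compounds go, whether an amine or a carboxylic acid in place of methoxy would shift the number remains open. So does the effect of a longer chain carrying the same phenyl.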